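Swapping the benzylic aryl for an isopropylsulfonylphenyl

The source may hold more compounds than are shown below. What is called first, only, known or untested is meant among the compounds shown, and "the series" means these compounds.

Three analogues sharing one core have been measured in a functional assay on NCI-H3122 cells (Homo sapiens) for antiproliferative activity, read by MTT assay, with a stated time of 48 h; on this read-out higher numbers stand for weaker inhibition and lower numbers for stronger inhibition. Compound 1 `CC(Oc1cccnc1Nc1cnn(C)c1)c1cccc(C(=O)NCc2ccc(OC(F)(F)F)cc2)c1` gives 8300 nM. Compound 2 `CC(Oc1cccnc1Nc1cnn(C)c1)c1cccc(C(=O)NCc2ccc(F)c(Cl)c2)c1` gives 35700 nM, and compound 3 `CC(Oc1cccnc1Nc1cnn(C)c1)c1cccc(C(=O)NCc2ccc(Cl)c(C(F)(F)F)c2)c1` gives 50700 nM. Compound 3 holds the highest number of the three: it lies a 1.4-fold higher number from compound 2 to compound 3 (0.15 log units; within the scatter) and a 6.1-fold higher number from compound 1 to compound 3 (0.79 log units; beyond the scatter), while the remaining step is a 4.3-fold higher number from compound 1 to compound 2 (0.63 log units; beyond the scatter).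

Compound 4 `CC(Oc1cccnc1Nc1cnn(C)c1)c1cccc(C(=O)NCc2ccccc2S(=O)(=O)C(C)C)c1` differs from compound 3 in one place: 2-(isopropylsulfonyl)phenyl in place of 4-chloro-3-(trifluoromethyl)phenyl on a saturated chain carbon bound to an amide-type nitrogen. Going by the values given here, no measured step covers this particular group; the only guidance is that the three aryl changes on the same carbon moved the read-out in this assay by modest amounts at most, with compound 1 sitting at the low end. A group carrying two hydrogen-bond acceptors has not been tried here, so the direction is open. Compound 4 is therefore estimated at 15000 nM, within a range from 3000 nM to 60000 nM. This corresponds to an expected 3.4-fold lower number from compound 3 to compound 4 (0.53 log units; beyond the scatter), a step of a size comparable to those already seen.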

Compound 4, half-maximal inhibitory concentration: > 100000 nM
Compound 4 gave a limit, no number; the forecaster's own chance of this, stated with the estimate: 15%; at least 6.6-fold (0.82 log units) between middle value and limit.
By their numbers in this assay, from the lowest: compound 1; then compounds 2 and 3 (each within the scatter of the next). At a limit, above all of these: compound 4.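

In this assay compound 4 yields a limit and not a number: the limit of > 100000 nM in this assay, at which 1 of the 4 values shown sits.

Read against that limit, placing 2-(isopropylsulfonyl)phenyl on this saturated chain carbon gives an at least 12-fold higher number from compound 1 to compound 4 (1.08 log units; beyond the scatter) and an at least 2.8-fold higher number from compound 2 to compound 4 (0.44 log units; beyond the scatter) and so produces the first step at this position that is large rather than modest. The remaining reading, an at least 1.9-fold higher number from compound 3 to compound 4 (0.29 log units; that floor lies within the scatter), has a floor too small to separate this group from 4-chloro-3-(trifluoromethyl)phenyl on its own.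

Because the change removes the halogens and brings in the sulfonyl at once, the compounds shown cannot tell which part of it matters. From the compounds shown here alone, how a methylsulfonyl, a sulfonamide or a carboxylic acid on this phenyl ring would read remains open, as does the actual number for compound 4.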